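Cytotoxicity notes: carbamoyl to oxetanylaminomethyl on the side chain

This account rests on a few compounds, and the source may have more. Where it says the series, first, only, none or still open, it means among the compounds named here.

Measured in an ADME assay on HEp-2 cells (Homo sapiens) for cytotoxicity, read by CCK-8 assay, with a stated time of 5 days; a higher number here means that more compound is tolerated, a lower number that less compound is tolerated:
- compound 1 `Cc1ccc2nc(N3CCCc4ccc(F)cc4C3)cc(NCC3(N)COC3)c2c1`, only a limit of the assay, > 100000 nM
- compound 2 `Cc1ccc2nc(N3CCCc4ccc(F)cc4C3)cc(NCC(C)(C)N)c2c1`, 23000 nM
- compound 3 `Cc1ccc2nc(N3CCCc4ccc(F)cc4C3)cc(NCC(N)=O)c2c1`, 22000 nM

Compound 3 holds the lowest of the two numbers; its nearest neighbour is compound 2, and a 1.0-fold lower number from compound 2 to compound 3 (0.02 log units; within the scatter) sits within the scatter. Compound 1 sits at the limit (the limit of > 100000 nM in this assay, at which 1 of the 3 values shown sits). Compound 4 `Cc1ccc2nc(N3CCCc4ccc(F)cc4C3)cc(NCCNC3COC3)c2c1` differs from compound 3 by ((oxetan-3-yl)amino)methyl in place of carbamoyl on a saturated chain carbon bound to a nitrogen on an aromatic ring. Within the data shown here, the steps that bear on this are an at least 4.5-fold lower number from compound 1 to compound 3 (0.65 log units; beyond the scatter) and an at least 4.3-fold lower number from compound 1 to compound 2 (0.63 log units; beyond the scatter), both at least modest and both running from the oxetane-bearing compound 1 towards lower numbers. Among the measured compounds shown here, no measured step covers the oxetan-3-ylamino link itself. Since compound 4 brings the four-membered ring back, a step of a 2.0-fold higher number from compound 3 to compound 4 (0.31 log units; beyond the scatter) towards a higher number is expected, of modest size. Compound 4 is therefore estimated at 45000 nM, within 15000 nM to 120000 nM.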

Compound 4, half-maximal cytotoxic concentration: > 100000 nM
Compound 4 ended at the assay's limit; the forecaster's own chance of this, stated with the estimate: 30%; middle value at least 2.2-fold (0.34 log units) away from the limit.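

In this assay, carbamoyl replaced by ((oxetan-3-yl)amino)methyl gives an at least 4.5-fold higher number from compound 3 to compound 4 (0.65 log units; beyond the scatter), and 1-amino-1-methylethyl replaced by the same group gives an at least 4.3-fold higher number from compound 2 to compound 4 (0.63 log units; beyond the scatter). The oxetane-bearing compound 1 and compound 4 now both give only a limit of the assay, not a number: the limit of > 100000 nM in this assay, at which 2 of the 4 values shown sit. The step between these two cannot be read, so their side chains cannot be ranked.

Still open, on these data alone, is whether the oxetane oxygen matters, as a cyclobutyl group in place of the oxetane would test. As far as these compounds go, a longer chain carrying the same ((oxetan-3-yl)amino) group also remains untested here.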